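From 4-methylphenyl to naphthalen-1-yl in compound 4

This account rests on a few compounds, and the source may have more. Where it says the series, first, only, none or still open, it means among the compounds named here.

Of the compounds shown here, three with a shared core have been tested in an ADME assay on GES1 cells (Homo sapiens) for inhibition, read by MTT assay, with a stated time of 72 h; on this read-out lower numbers stand for stronger inhibition and higher numbers for weaker inhibition. Compound 1 `Cc1cc(Nc2cc(-c3ccccc3)[nH]n2)n2nc(SCc3c(Cl)cccc3Cl)nc2n1` gives 39600 nM, compound 2 `Cc1cc(Nc2cc(-c3ccccc3)[nH]n2)n2nc(SCCCc3ccccc3)nc2n1` gives 40200 nM, and compound 3 `Cc1ccc(CSc2nc3nc(C)cc(Nc4cc(-c5ccccc5)[nH]n4)n3n2)cc1` gives 36200 nM. Compound 3 therefore stands level with the other two, since its number lies within the usual scatter of both.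

Compound 4 `Cc1cc(Nc2cc(-c3ccccc3)[nH]n2)n2nc(SCc3cccc4ccccc34)nc2n1` keeps the core and changes one group: naphthalen-1-yl in place of 4-methylphenyl on a saturated chain carbon bound to a sulfur.

The measured steps at this same place are the best guide. They are a 1.1-fold lower number from compound 1 to compound 3 (0.04 log units; within the scatter), a 1.1-fold lower number from compound 2 to compound 3 (0.05 log units; within the scatter) and a 1.0-fold higher number from compound 1 to compound 2 (0.01 log units; within the scatter), and all three lie within the scatter. None of the tested groups has two aromatic rings, so the guide is imperfect.

Even so, no shift beyond the scatter is expected in this assay. The expected step is a 1.0-fold lower number from compound 3 to compound 4 (0.01 log units; within the scatter). For compound 4 the estimated value is 35000 nM, with an expected range from 18000 nM to 65000 nM.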

Compound 4, half-maximal inhibitory concentration: 36300 nM
Compound 4: middle estimate off by 1.0-fold (0.02 log units), on the low side, and the stated range covers the measured number.
By their numbers in this assay, from the lowest: compounds 3, 4, 1 and 2 (each within the scatter of the next).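

In this assay, a second aromatic ring on a saturated chain carbon bound to a sulfur leaves compound 3 and compound 4 level (a 1.0-fold higher number from compound 3 to compound 4 (0.00 log units; within the scatter)), so naphthalen-1-yl, with its 10 heavy atoms, reads the same here as 4-methylphenyl with its 7. Compound 4 also stands level with the other two compounds (a 1.1-fold lower number from compound 2 to compound 4 (0.04 log units; within the scatter); a 1.1-fold lower number from compound 1 to compound 4 (0.04 log units; within the scatter)), which extends the flat picture at this place to all four groups shown. No measurement at hand explains this flatness.

The groups shown here are all built on aromatic carbon rings, so whether an amine or a carboxylic acid at this place would give a number beyond the scatter remains open. Going by these compounds, whether a change elsewhere on the shared core would do so also remains open.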